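The source may hold more compounds than are shown below. What is called first, only, known or untested is meant among the compounds shown, and "the series" means these compounds.

Compound 1 `CC(C)C(=O)Nc1ccc(S(=O)(=O)Oc2ccccc2C(C)C)cc1` was tested in a functional assay on MCF7 cells (Homo sapiens) for antiproliferative activity, read by sulforhodamine B assay, with a stated time of 48 h (on this read-out lower numbers stand for stronger inhibition and higher numbers for weaker inhibition), and gives 8600 nM. Compound 2 `CC(C)C(=O)Nc1ccc(S(=O)(=O)Oc2ccccc2I)cc1` gives 8100 nM, and compound 3 `O=C(CCCl)Nc1ccc(S(=O)(=O)Oc2ccccc2I)cc1` gives 8900 nM; all three numbers sit within the usual scatter of one another, so compound 1 cannot be told apart from the other two on these numbers. The change leading to compound 4 `CCCNC(=O)Nc1ccc(S(=O)(=O)Oc2ccccc2C(C)C)cc1` is propylamino in place of isopropyl on a carbonyl carbon. The step of a 1.1-fold higher number from compound 2 to compound 3 (0.04 log units; within the scatter) altered the same carbonyl carbon, and the step of a 1.1-fold lower number from compound 1 to compound 2 (0.03 log units; within the scatter) altered an aromatic carbon instead; neither moved the read-out beyond the scatter. The change to compound 4 is therefore expected to give no step beyond the scatter, no change at the digits printed from compound 1 to compound 4 (within the scatter). Compound 4 is estimated at 8600 nM, within a range from 4000 nM to 18000 nM.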

Compound 4, half-maximal inhibitory concentration: 2700 nM
The estimate for compound 4 lay 3.2-fold (0.50 log units) above the measured number; measured number below the stated range.
By their numbers in this assay, from the lowest: compound 4; then compounds 2, 1 and 3 (each within the scatter of the next).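

Propylamino in place of isopropyl on this carbonyl carbon gives a 3.2-fold lower number from compound 1 to compound 4 (0.50 log units; beyond the scatter) and so stronger inhibition, the first step in this set beyond the scatter. It shows that this carbonyl carbon can influence the read-out, which the 2-chloroethyl change at the same carbon did not show. No evidence available here explains the shift.

Still open, on these data alone, is whether the gain depends on the added nitrogen and its hydrogen or on the chain, which a butyl group or a dimethylamino group at this carbon would help separate. As far as these compounds go, whether propylamino acts the same way alongside iodo, in place of isopropyl on the aromatic carbon, also remains open.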